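A Fluoro Substituent Added to the Shared Core of Compound 2

The source may hold more compounds than are shown below. What is called first, only, known or untested is meant among the compounds shown, and "the series" means these compounds.

Going by the values given here, the three compounds measured so far share one core and differ only in the aryl group on the aromatic nitrogen. Compound 1 `Cc1cc(=O)n(-c2ccc(Br)cc2F)nc1C(=O)Nc1ccc(Oc2ncnc3c2ccn3C)cc1` carries a 4-bromo-2-fluorophenyl there and gives 33600 nM in a functional assay on HepG2 cells (Homo sapiens) for cytotoxicity, read by MTT assay, with a stated time of 72 h; a lower number here means a stronger inhibitor, a higher number a weaker inhibitor. Compound 3 `Cc1cc(=O)n(-c2ccccc2Cl)nc1C(=O)Nc1ccc(Oc2ncnc3c2ccn3C)cc1` carries a 2-chlorophenyl and gives 11200 nM in this assay. Compound 2 `Cc1cc(=O)n(-c2cccc(F)c2)nc1C(=O)Nc1ccc(Oc2ncnc3c2ccn3C)cc1` carries a 3-fluorophenyl; in this assay compound 2 reaches only a limit of the assay, > 60000 nM, so no number stands for it. That limit is the limit of > 60000 nM in this assay, at which 1 of the 3 values shown sits. The measured steps are an at least 1.7-fold higher number from compound 1 to compound 2 (0.25 log units; that floor lies within the scatter), a 3.0-fold lower number from compound 1 to compound 3 (0.48 log units; beyond the scatter) and an at least 5.3-fold lower number from compound 2 to compound 3 (0.72 log units; beyond the scatter).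

Compound 4 `Cc1cc(=O)n(-c2cccc(F)c2)nc1C(=O)Nc1ccc(Oc2ncnc3c2ccn3C)c(F)c1` differs from compound 2 in one place: fluoro in place of hydrogen on an aromatic carbon, on an aromatic carbon of a six-membered aromatic ring of carbon only, ortho to a large group and meta to a large group. Among the compounds with values here, none of the measured steps touches this ring; all of them exchange the aryl group on the aromatic nitrogen, and the two steps beyond the scatter concern the 2-chlorophenyl of compound 3. Within the data shown here, no step therefore bears directly on this change, and a single fluoro is expected to move this assay by no more than the scatter, in either direction. Compound 4 is thus expected near 60000 nM, within 30000 nM to 120000 nM, and the expected step is a number no higher from compound 2 to compound 4 (the limit leaves the size open), most likely again only a limit of the assay.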

Compound 4, half-maximal inhibitory concentration: > 60000 nM
Compound 4 gave a limit, no number (the forecaster's own chance of this, stated with the estimate: 65%); the middle value sits exactly at the limit.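

Compound 2 and compound 4 both give only a limit in this assay, not a number, so no step can be read between them: the limit of > 60000 nM in this assay, at which 2 of the 4 values shown sit. The compounds shown leave open how far either compound lies past that limit, and whether the added fluoro moves the result in this assay at all.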